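The source may hold more compounds than are shown below. What is called first, only, known or untested is meant among the compounds shown, and "the series" means these compounds.

For the measured compounds named here, compound 2 `C=CCn1c(=O)/c(=C\c2cc(F)ccc2C)[nH]c(=O)/c1=C\c1ccccc1OC` gives 7300 nM in a functional assay on NCI-H1975 cells (Homo sapiens) for cytotoxicity, read by CCK-8 assay, with a stated time of 72 h (on this read-out lower numbers stand for stronger inhibition and higher numbers for weaker inhibition), the second highest of the three numbers known. Its nearest neighbour is compound 1 `C=CCn1c(=O)/c(=C\c2cccc(C)c2)[nH]c(=O)/c1=C\c1ccccc1OC` with 32800 nM; the furthest is compound 3 `COc1ccccc1/C=c1\c(=O)[nH]/c(=C/c2ccccc2Cl)c(=O)n1C` with 200 nM. Going by the values given here, the one measured step, a 4.5-fold lower number from compound 1 to compound 2 (0.65 log units; beyond the scatter), changed the group at the same place that is altered now. Compound 4 `C=CCn1c(=O)/c(=C\c2ccccc2OC)[nH]c(=O)/c1=C\c1ccccc1OC` differs from compound 2 as follows: 2-methoxyphenyl in place of 5-fluoro-2-methylphenyl on a double-bonded chain carbon bound to an aromatic carbon. Among the compounds with values here, no measured step covers the entry of 2-methoxyphenyl at this place, and compound 3 differs from compound 2 in more than one place, so only its value can be noted. The expected step is therefore small, a 1.2-fold higher number from compound 2 to compound 4 (0.09 log units; within the scatter), in either direction. Compound 4 is expected to give about 9000 nM, within 2500 nM to 30000 nM.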

Compound 4, half-maximal inhibitory concentration: 21500 nM
For compound 4 the middle estimate is 2.4-fold (0.38 log units) below the measured one; measured number inside the range.
By their numbers in this assay, from the lowest: compound 3; then compound 2; then compounds 4 and 1 (each within the scatter of the next).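

At this place on a double-bonded chain carbon bound to an aromatic carbon, 2-methoxyphenyl weakens inhibition relative to 5-fluoro-2-methylphenyl in this assay (a 2.9-fold higher number from compound 2 to compound 4 (0.47 log units; beyond the scatter)). Against 3-methylphenyl, the same group gives no real separation (a 1.5-fold lower number from compound 1 to compound 4 (0.18 log units; within the scatter)), so among these three groups only 5-fluoro-2-methylphenyl stands apart. Nothing available explains this difference. Going by these compounds, it remains open how a group without a phenyl ring, such as an amine or a carboxylic acid, would behave at this place on the shared core.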